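From Isopropylcarbonyl to Benzoyl: One Step, One Open Number

The compounds below may be only part of what the source reports. "The series", "measured", "known", "first", "only" and "open" are said of these compounds alone.

For the measured compounds named here, in an ADME assay on MRC5 cells (Homo sapiens) for cytotoxicity, read by neutral red uptake, with a stated time of 24 h (on this read-out higher numbers stand for weaker inhibition and lower numbers for stronger inhibition), compound 1 `CC(C)C(=O)Oc1c(C(C)C)cc2c3c1OC(=O)[C@@]31CCCC(C)(C)[C@@H]1CC2` gives 119000 nM and this is the only true number available so far. Compound 2 `CCCCCCCC/C=C/CCCCCCCC(=O)Oc1c(C(C)C)cc2c3c1OC(=O)[C@@]31CCCC(C)(C)[C@@H]1CC2` reaches > 1000000 nM in this assay and that figure is a limit of the assay. Compound 3 `CC(C)c1cc2c3c(c1OC(=O)c1ccccc1)OC(=O)[C@@]31CCCC(C)(C)[C@@H]1CC2` has not been measured yet. It shares the core of compound 1 and differs in one place: phenyl in place of isopropyl on a carbonyl carbon so that isopropylcarbonyl becomes benzoyl. Going by the values given here, no measured pair shows what such a swap does, so the expectation rests on compound 1 at 119000 nM alone. The estimated step of a 1.0-fold higher number from compound 1 to compound 3 (0.00 log units; within the scatter) stays within the usual scatter of repeated measurements, with no shift expected in either direction. For compound 3 the expected value is 120000 nM with a likely range from 40000 nM to 400000 nM once it is measured.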

Compound 3, half-maximal inhibitory concentration: 512000 nM
Compound 3: middle estimate off by 4.3-fold (0.63 log units), on the low side; the measured number lies above the stated range.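

Phenyl in place of isopropyl on a carbonyl carbon gives a 4.3-fold higher number from compound 1 to compound 3 (0.63 log units; beyond the scatter) in this assay and this is the first change at this position that can be read as a number. Higher numbers here stand for weaker inhibition, so what sits on this carbonyl carbon can move the read-out beyond the scatter, in the direction of weaker inhibition for this one swap. For the compounds shown here, compound 2 carries a limit and not a number, so no step to it can be read: the limit of > 1000000 nM in this assay, at which 1 of the 3 values shown sits.

A single step cannot tell whether the ring, the larger size of the group or something else moves the number. As far as these compounds go, how a methyl group, an amine or a carboxylic acid would read at this position remains open.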